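Swapping the Aryl Amide in a Thiourea Series

The source may report more compounds than this note shows. Statements on the series, on what has been measured and on what is new or still open speak of the compounds shown alone.

Compound 1 `O=C(NC(=S)N1CCc2c(OCCCCCOc3ccc(Cl)cc3)cccc21)c1ccc2ccccc2c1` gives > 50000 nM in an ADME assay on Huh-7 cells (Homo sapiens) for cytotoxicity (a higher number here means that more compound is tolerated, a lower number that less compound is tolerated), which is a limit of the assay rather than a number.
Compound 2 `O=C(NC(=S)N1CCc2c(OCCCCCOc3ccc(Cl)cc3)cccc21)c1ccco1` gives 4620 nM in this assay.

Among the measured compounds shown here, compound 2 therefore holds the only actual number, and the limit of > 50000 nM in this assay, at which 1 of the 2 values shown sits, shows that the other value is a limit. For the measured compounds named here, the step of an at least 10-fold lower number from compound 1 to compound 2 (1.03 log units; beyond the scatter) is the sole measured change. Compound 3 `O=C(NC(=S)N1CCc2c(OCCCCCOc3ccc(Cl)cc3)cccc21)c1cccnc1` carries pyridin-3-yl in place of furan-2-yl on a carbonyl carbon. Going by the values given here, no measured step covers this exchange, so it is taken as neutral. Compound 3 is expected to show 8000 nM, between 2500 nM and 30000 nM, an estimated step of a 1.7-fold higher number from compound 2 to compound 3 (0.24 log units; within the scatter).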

Compound 3, half-maximal cytotoxic concentration: 11100 nM
Estimate against measurement, compound 3: 1.4-fold (0.14 log units) below; low and high end bracket the measured number.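

Changing only the group on the carbonyl carbon, pyridin-3-yl in place of furan-2-yl gives a 2.4-fold higher number from compound 2 to compound 3 (0.38 log units; beyond the scatter) in this assay, so this position separates even two single-ring groups. Pyridin-3-yl in place of naphthalen-2-yl gives an at least 4.5-fold lower number from compound 1 to compound 3 (0.65 log units; beyond the scatter), which places compound 3 between the other two compounds. Compound 1 carries a limit of the assay, not a number, so the full size of that step stays open: the limit of > 50000 nM in this assay, at which 1 of the 3 values shown sits.

Left open is what a plain phenyl ring or a pyridin-4-yl ring would give on the same carbonyl carbon.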